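The source may report more compounds than this note shows. Statements on the series, on what has been measured and on what is new or still open speak of the compounds shown alone.

Working notes on the series. Compound 1 `c1ccc(CNCC2CCN(CCCc3c[nH]c4ccc(-n5cnnc5)cc34)CC2)cc1`, compound 2 `CN(Cc1cccs1)C1CCN(CCCc2c[nH]c3ccc(-n4cnnc4)cc23)CC1` and compound 3 `c1ccc2c(c1)CCC2NC1CCN(CCCc2c[nH]c3ccc(-n4cnnc4)cc23)CC1` share one core and differ only in the substituent on the saturated ring carbon. In a functional assay on CHO cells for activation of 5-hydroxytryptamine receptor 1D (Homo sapiens), read by GTPgammaS binding (a higher number here means a larger maximal response, a lower number a smaller maximal response), compound 1 gives 101%, compound 2 gives 81% and compound 3 gives 68%. Compound 3 therefore stands lowest of the three numbers, reached by the steps of a number 33 percentage points lower from compound 1 to compound 3 (beyond the scatter) and a number 13 percentage points lower from compound 2 to compound 3 (beyond the scatter); the third comparison is a number 20 percentage points lower from compound 1 to compound 2 (beyond the scatter). Compound 4 `NC(=O)OC[C@H](NC1CCN(CCCc2c[nH]c3ccc(-n4cnnc4)cc23)CC1)c1ccccc1` continues from compound 3 with 2-(carbamoyloxy)-1-phenylethyl in place of 2,3-dihydro-1H-inden-1-yl on an amine nitrogen. Both measured steps into compound 3 were downward beyond the scatter, so the 2,3-dihydro-1H-inden-1-yl group marks the low end of what this position has given. The entering 2-(carbamoyloxy)-1-phenylethyl group again carries one six-membered aromatic ring of carbon only, as does the (benzylamino)methyl of compound 1, which sits at the top of the range. Going by the values given here, a rise is expected, but its size is uncertain since no step with this exact group is available. Compound 4 is expected to give 85%, within 65% to 105%, an expected step of a number 17 percentage points higher from compound 3 to compound 4 (beyond the scatter).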

Compound 4, largest response reached (reported as efficacy), in percent of the reference or control that the assay uses: 73%
Compound 4: the middle estimate sits 12 percentage points above what was measured; the measured number falls inside the stated range.
By their numbers in this assay, from the lowest: compounds 3, 4 and 2 (each within the scatter of the next, the first and the last beyond it); then compound 1.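

In this assay, 2-(carbamoyloxy)-1-phenylethyl in place of 2,3-dihydro-1H-inden-1-yl on the amine nitrogen gives a number 5 percentage points higher from compound 3 to compound 4 (within the scatter), so this position tolerates the loss of the five-membered non-aromatic ring and the gain of a carbamoyloxy group, with its hydrogen-bond donor and acceptors, without a separable change in maximal response. Retaining a six-membered aromatic ring of carbon only in the entering group therefore brings no separable rise over compound 3. No supporting data bear on this result.

The compounds shown leave open whether the carbamoyloxy group and the defined stereocentre each contribute to the value of compound 4. A hydroxyl in place of carbamoyloxy, or the opposite configuration at that stereocentre, would test this in this assay.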